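The source may report more compounds than this note shows. Statements on the series, on what has been measured and on what is new or still open speak of the compounds shown alone.

Compound 1 `Cc1ccc(S(=O)(=O)c2cnc3cc(F)ccc3c2N2CCC(C)CC2)cc1Cl` gives 93%; compound 2 `CC1CCN(c2c(S(=O)(=O)c3ccc(F)c(F)c3)cnc3cc(F)ccc23)CC1` gives 94%; compound 3 `CC1CCN(c2c(S(=O)(=O)c3ccc(F)c(F)c3)cnc3ccc(Cl)cc23)CC1` gives 72%.

All three were tested in an assay on isolated protein for displacement of a labelled ligand from metabotropic glutamate receptor 5 (Homo sapiens), with a stated time of 60 min, tested at 1 uM; a lower number here means less inhibition, a higher number more inhibition at the concentration tested (going by the name of the read-out). Compound 2 and compound 1 share a core and differ in one place, (3-chloro-4-methylphenyl in place of 3,4-difluorophenyl on a sulfonyl sulfur). This change gave a number 1 percentage points lower from compound 2 to compound 1 (within the scatter), so the two numbers cannot be told apart. Compound 3 carries a different core from compound 2; the difference between the two cores is not broken down here. In this assay compound 3 gives the lowest of the three numbers, and its gaps to both compound 1 and compound 2 lie beyond the scatter.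

Compound 4 `Cc1ccc(S(=O)(=O)c2cnc3ccc(Cl)cc3c2N2CCC(C)CC2)cc1Cl` has not been measured. It relates to compound 3 as compound 1 relates to compound 2: 3-chloro-4-methylphenyl in place of 3,4-difluorophenyl on a sulfonyl sulfur, at the same place in both pairs, so this is the same change. Because that change gave a number 1 percentage points lower from compound 2 to compound 1 (within the scatter), the step from compound 3 to compound 4 is expected to be similarly small, about a number 1 percentage points lower from compound 3 to compound 4 (within the scatter). Compound 4 is therefore estimated at 71% in this assay, most likely between 57% and 85%.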

Compound 4, a percentage reported as inhibition, at one concentration (the size of the read-out at that concentration, not a potency): 81%
For compound 4 the middle estimate is 10 percentage points below the measured one, and the stated range covers the measured number.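

In this assay, putting 3-chloro-4-methylphenyl in place of 3,4-difluorophenyl on a sulfonyl sulfur gave a number 9 percentage points higher from compound 3 to compound 4 (within the scatter) and so left the two numbers unresolved. On neither core did the change shift the number beyond the scatter, and the two steps themselves cannot be told apart, so within these two pairs it carried from one core to the other without a detectable difference: the same change on two cores in this assay, a number 1 percentage points lower (within the scatter) from compound 2 to compound 1 and a number 9 percentage points higher (within the scatter) from compound 3 to compound 4, 10 percentage points apart, within the scatter of two such steps. These two pairs do not show that the change has no effect at all, nor that it would behave the same way on any further core.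

The compounds shown leave open whether an aryl group carrying a nitrile or a carboxylic acid, set on the sulfonyl sulfur, would give a similar number. They also leave open whether the gap seen between compound 2 and compound 3 would persist with such groups in place.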